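A few compounds are considered here, and "the series" means these few. Any claim that something is new, unique, unknown or untested is made for them only; others in the source may bear on it.

Of the compounds shown here, three from this series have been tested in a functional assay on A549 cells (Homo sapiens) for cytotoxicity, read by colorimetric assay and MTT assay, with a stated time of 3 days, tested at 20 uM; a higher number here means a weaker effect of the compound at the concentration tested, a lower number a stronger effect. Compound 1 `O=C1COc2ccc(-c3[nH]c(-c4ccc(F)cc4)nc3-c3ccccc3)cc2N1` gives 37.5%, the lowest of the three numbers. Compound 2 `COc1ccc(-n2cc(-c3ccccc3)c(-c3ccc4c(c3)NC(=O)CO4)n2)cc1` gives 42.6%, which lies within the scatter of the value of compound 1. Compound 3 `O=C1COc2ccc(-c3nn(-c4ccccc4)cc3-c3ccccc3)cc2N1` gives 59.7%, the furthest from compound 1 and beyond the scatter. Among the compounds with values here, the only single change measured so far is a number 17.1 percentage points higher from compound 2 to compound 3 (beyond the scatter).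

Compound 4 `O=C1COc2ccc(-c3[nH]c(-c4ccc(Cl)cc4Cl)nc3-c3ccccc3)cc2N1` differs from compound 1 in one place: 2,4-dichlorophenyl in place of 4-fluorophenyl on an aromatic carbon. Within the data shown here, no measured step covers this kind of change; the one measured step concerns a different group on a different core, so it offers no direct guide. With no evidence pointing in either direction, the expectation is a step of a number 2.5 percentage points higher from compound 1 to compound 4 (within the scatter), that is, no change beyond the scatter, though the range must be wide. Compound 4 is therefore estimated to give 40% in this assay, with a range from 20% to 62%.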

Compound 4, a percentage reported as activity, at one concentration (the size of the read-out at that concentration, not a potency): 68.3%
Beside the measured number, compound 4's estimate is 28.3 percentage points below it; measured number outside the range, above it.
By their numbers in this assay, from the lowest: compounds 1 and 2 (each within the scatter of the next); then compounds 3 and 4 (each within the scatter of the next).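

On the aromatic carbon between two ring nitrogen atoms, 2,4-dichlorophenyl in place of 4-fluorophenyl gives a number 30.8 percentage points higher from compound 1 to compound 4 (beyond the scatter) in this assay, which means a weaker effect at the concentration tested. Within the data shown here, none of the earlier compounds varied this position, so this is the first sign that the effect depends on what the phenyl ring here carries. Nothing measured explains the step.

This single change swaps fluorine for chlorine and also adds a second halogen, so the compounds shown cannot separate the contribution of the kind of halogen from that of the number of halogens. From the compounds shown here alone, a phenyl ring with a single chlorine would help separate them, and how a phenyl ring carrying an amine would behave at this position remains open.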